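The source may hold more compounds than are shown below. What is called first, only, known or untested is meant among the compounds shown, and "the series" means these compounds.

Compound 2 `Cc1cc(N2CCCC2)c(S(C)(=O)=O)cc1C(=O)N=C(N)N` gives the lowest of the two numbers measured in a functional assay for inhibition of sodium/hydrogen exchanger (Oryctolagus cuniculus) (a lower number here means a stronger inhibitor, a higher number a weaker inhibitor), with compound 2 at 11 nM; its nearest neighbour is compound 1 `Cc1cc(Sc2ccccc2Cl)c(S(C)(=O)=O)cc1C(=O)N=C(N)N`, which in this assay gives 14 nM, a gap within the scatter. Compound 3 `Cc1cc(-n2ccnc2C)c(S(C)(=O)=O)cc1C(=O)N=C(N)N` carries 2-methyl-1H-imidazol-1-yl in place of pyrrolidin-1-yl on an aromatic carbon. Within the data shown here, the only step that bears on this change is a 1.3-fold lower number from compound 1 to compound 2 (0.10 log units; within the scatter), which swapped the same position and moved the number only within the scatter. A step within the scatter is therefore expected, a 1.4-fold higher number from compound 2 to compound 3 (0.13 log units; within the scatter). Compound 3 is expected to give 15 nM, with a range from 5 nM to 45 nM.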

Compound 3, half-maximal inhibitory concentration: 29 nM
The estimate for compound 3 lay 1.9-fold (0.29 log units) below the measured number; measured number inside the range.
By their numbers in this assay, from the lowest: compounds 2 and 1 (each within the scatter of the next); then compound 3.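

Among these compounds, replacing pyrrolidin-1-yl with 2-methyl-1H-imidazol-1-yl is the first change at this position to move the number beyond the scatter in this assay (a 2.6-fold higher number from compound 2 to compound 3 (0.42 log units; beyond the scatter)). The same holds when it replaces (2-chlorophenyl)sulfanyl (a 2.1-fold higher number from compound 1 to compound 3 (0.32 log units; beyond the scatter)), so the group at this position can matter, though both steps are modest. Nothing available explains the rise.

On these data alone, it remains open whether the higher number goes with the methyl group or the aromatic ring. Plain 1H-imidazol-1-yl, without the methyl group, would separate the two, while an open-chain amine such as dimethylamino would test whether any ring is needed here.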